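From Bromo to Chloro in a Small Series

The source may hold more compounds than are shown below. What is called first, only, known or untested is meant among the compounds shown, and "the series" means these compounds.

- Compound 1 `COc1cc2c(cc1OC)C(c1cccc(N)c1)=NN=C(S)C2`: 9.1 umol/kg
- Compound 2 `COc1cc2c(cc1OC)C(c1ccc(N)cc1)=NN=C(S)C2`: 3.3 umol/kg
- Compound 3 `COc1cc2c(cc1OC)C(c1ccc(Br)cc1)=NN=C(S)C2`: 33.3 umol/kg

In a functional assay on the whole organism with Mus musculus as the target (on this read-out lower numbers stand for an effect already at smaller amounts and higher numbers for an effect only at larger amounts of compound), compound 3 gives 33.3 umol/kg, the highest of the three numbers. Compound 4 `COc1cc2c(cc1OC)C(c1ccc(Cl)cc1)=NN=C(S)C2` differs from it by one exchange: chloro in place of bromo on an aromatic carbon. Among the measured compounds shown here, no measured step puts chloro in place of bromo. The nearest evidence is a 10-fold higher number from compound 2 to compound 3 (1.00 log units; beyond the scatter), with bromo in place of amino, and a 3.7-fold higher number from compound 1 to compound 3 (0.56 log units; beyond the scatter), with 4-bromophenyl in place of 3-aminophenyl. Both swaps involve amino, which is absent from the present exchange, so they offer only a loose guide. The counted difference shows the two groups alike apart from the element itself. The expected step is a 1.2-fold lower number from compound 3 to compound 4 (0.08 log units; within the scatter), within the scatter of this assay. For compound 4 the estimated value is 28 umol/kg, with an expected range of 12 umol/kg to 65 umol/kg.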

Compound 4, dose for half-maximal effect: 55 umol/kg
Beside the measured number, compound 4's estimate is 2.0-fold (0.29 log units) below it; measured number inside the range.
By their numbers in this assay, from the lowest: compound 2; then compound 1; then compounds 3 and 4 (each within the scatter of the next).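

Chloro and bromo on this aromatic carbon cannot be told apart (a 1.7-fold higher number from compound 3 to compound 4 (0.22 log units; within the scatter)). Chloro stands as far from amino as bromo does (a 17-fold higher number from compound 2 to compound 4 (1.22 log units; beyond the scatter)), and the step from the other amino compound, with 4-chlorophenyl in place of 3-aminophenyl, is also beyond the scatter (a 6.0-fold higher number from compound 1 to compound 4 (0.78 log units; beyond the scatter)). No measurement shown explains why the amino compounds give lower numbers than the two halogen compounds.

As far as these compounds go, it stays open whether a hydroxyl or a dimethylamino group at this place would give numbers like those of amino or like those of chloro and bromo.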